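A few compounds are considered here, and "the series" means these few. Any claim that something is new, unique, unknown or untested is made for them only; others in the source may bear on it.

Compound 1 `CC[C@@H](Nc1c(C#N)c(-c2ccc(-c3ncccc3C)cc2)nc2cnccc12)C(N)=O` gives 2 in a physicochemical assay for lipophilicity, read by HPLC, at pH 7.5 (a higher number here means a more lipophilic compound, a lower number a more polar compound), the lowest of the three numbers in hand. Compound 2 `CC[C@H](Nc1c(C#N)c(-c2ccc(Br)cc2)nc2cnccc12)C(N)=O` gives 2.3, which sits within the scatter of compound 1, so no order between the two is claimed. Compound 3 `CCOc1ccccc1-c1ccc(-c2nc3cnccc3c(N[C@H](CC(C)C)C(N)=O)c2C#N)cc1` gives 3.4, a number beyond the scatter above compound 1. Compound 4 `CC[C@@H](Nc1c(C#N)c(-c2ccc(-c3cnccc3C)cc2)nc2cnccc12)C(N)=O` awaits measurement in this assay. Against compound 1 it differs in one place: 4-methylpyridin-3-yl in place of 3-methylpyridin-2-yl on an aromatic carbon. The two have the same atoms, joined differently. Among the measured compounds shown here, no measured pair among compounds 1, 2 and 3 shows a change of this kind, so no step on record sets the size. Expected is a step of a number 0.10 log units higher from compound 1 to compound 4 (within the scatter), not beyond the scatter in either direction. Compound 4 is estimated at 2.1, in the range 1.7 to 2.5.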

Compound 4, distribution coefficient: 2
Compound 4: the middle estimate sits 0.10 log units above what was measured, within the range that was stated.
By their numbers in this assay, from the lowest: compounds 1, 4 and 2 (each within the scatter of the next); then compound 3.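

In this assay, among the compounds shown here, the exchange of 3-methylpyridin-2-yl for 4-methylpyridin-3-yl gives no change at the digits printed from compound 1 to compound 4 (within the scatter) and is the first step on record at this position, on an aromatic carbon para to a large group. For this one pair, joining the same atoms differently moves the read-out by no more than the scatter. Nothing on record gives a reason for this result.

On these data alone, whether a carboxylic acid or an amine at this position would give a step beyond the scatter stays open. Also open, as far as these compounds go, is whether this exchange gives a similar step with a longer chain elsewhere on the core.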